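This account rests on a few compounds, and the source may have more. Where it says the series, first, only, none or still open, it means among the compounds named here.

Values in a functional assay on MKN-45 cells (Homo sapiens) for inhibition, read by sulforhodamine B assay, with a stated time of 48 h (a lower number here means a stronger inhibitor of growth, a higher number a weaker inhibitor of growth), so far:
compound 1 `CCCCCCCCCCCC[C@@H](O)[C@H]1CC[C@H]([C@H](O)CCCCCCCCCCNCc2ccnn2C)O1` gives 1820 nM
compound 2 `CCCCCCCCCCCC[C@@H](O)[C@H]1CC[C@H]([C@H](O)CCCCCCCCCCC(=O)Nc2ccnn2C)O1` gives 100000 nM

Compound 2 holds the higher number of the pair and is the weaker inhibitor of growth. The change to compound 3 `CCCCCCCCCCCC[C@@H](O)[C@H]1CC[C@H]([C@H](O)CCCCCCCCCCOC(=O)c2ccnn2C)O1` is ((1-methyl-1H-pyrazol-5-yl)carbonyl)oxy in place of (1-methyl-1H-pyrazol-5-yl)carbamoyl on a saturated chain carbon, ten or more bonds along the chain from an oxygen on a saturated carbon and a saturated ring carbon on a saturated chain carbon, with the rest of the molecule unchanged. Among the compounds with values here, one measured step bears on this, and only indirectly: the change at this same place gave a 55-fold higher number from compound 1 to compound 2 (1.74 log units; beyond the scatter) and is large, beyond the scatter. Within the data shown here, it shows that this assay responds strongly to this place, but no measured compound yet carries the ((1-methyl-1H-pyrazol-5-yl)carbonyl)oxy group, so the direction remains uncertain. With compound 2 at 100000 nM as the higher number, a fall is expected more than a rise. The estimate is a 5.0-fold lower number from compound 2 to compound 3 (0.70 log units; beyond the scatter) in the direction of stronger inhibition. Compound 3 is expected at 20000 nM within an estimated range of 3000 nM to 100000 nM as the working figure.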

Compound 3, concentration for 50% growth inhibition: 100000 nM
The estimate for compound 3 lay 5.0-fold (0.70 log units) below the measured number; the measured number falls inside the stated range.
By their numbers in this assay, from the lowest: compound 1; then compounds 2 and 3 (each within the scatter of the next).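

In this assay, ((1-methyl-1H-pyrazol-5-yl)carbonyl)oxy in place of (1-methyl-1H-pyrazol-5-yl)carbamoyl gives no change at the digits printed from compound 2 to compound 3 (within the scatter) and so leaves the reading unmoved, although the hydrogen-bond donor counted on the carbamoyl group is gone. Set against the ((1-methyl-1H-pyrazol-5-yl)methyl)amino group, the new group shows a 55-fold higher number from compound 1 to compound 3 (1.74 log units; beyond the scatter) in the same assay, so among these compounds the large step now appears with two different replacements rather than one. No measured evidence accounts for this result.

From the compounds shown here alone, whether a tertiary amine or an ether at this place would give a number close to that of compound 1 at 1820 nM remains open. Also open, going by these compounds, is whether the ((1-methyl-1H-pyrazol-5-yl)methyl)amino result would hold with a phenyl ring in place of the pyrazole, or with a longer chain.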